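Methyl in place of hydrogen on the phenyl of compound 2

The source may report more compounds than this note shows. Statements on the series, on what has been measured and on what is new or still open speak of the compounds shown alone.

Working notes on a short sulfonyl pyrazole series read in a functional assay, read by Griess assay, with a stated time of 150 min, tested at 75 ug/mL; a lower number here means a weaker effect, a higher number a stronger effect of the compound at the concentration tested. Compound 1 `O=S(=O)(CC1=NCCS1)c1n[nH]cc1-c1ccccc1` is reported in this assay as "not active" (no number reported), without a number. Compound 2 `O=S(=O)(CC1=NCCO1)c1n[nH]cc1-c1ccccc1` gives 54.7% in this assay. Compound 3 `Cc1ccc(C2CNN=C2S(=O)(=O)CC2=NCCO2)cc1` gives 49.7%. Compound 2 stands at the top of the two numbers shown, with compound 3 within the scatter of it, so no order between the two is read. Compound 4 `Cc1ccc(-c2c[nH]nc2S(=O)(=O)CC2=NCCO2)cc1` awaits measurement and differs from compound 2 in one place: methyl in place of hydrogen on an aromatic carbon. Within the data shown here, no step between measured compounds covers this change, so only a small step, or none beyond the scatter, is expected. For compound 4 the expected step is a number 4.7 percentage points lower from compound 2 to compound 4 (within the scatter) because compound 3 with its methyl gives 49.7%. Compound 4 is estimated at 50%, in a range from 35% to 65%.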

Compound 4, a percentage reported as activity, at one concentration (the size of the read-out at that concentration, not a potency): 63.5%
For compound 4 the middle estimate is 13.5 percentage points below the measured one, within the range that was stated.
By their numbers in this assay, from the lowest: compounds 3, 2 and 4 (each within the scatter of the next, the first and the last beyond it).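

In this assay, among these compounds, the change from phenyl to 4-methylphenyl gives a number 8.8 percentage points higher from compound 2 to compound 4 (within the scatter), the first step that can be read at this place on the shared core. A methyl on this aromatic carbon, para to a large group, thus leaves the read-out within the usual scatter, with no readable loss or gain. No measurement at hand bears on the reason for this step. On these data alone, whether an amine, a carboxylic acid or a longer chain in place of the methyl would keep the read-out remains open. One step also cannot show whether the same methyl would behave alike on the core of compound 1.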